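The compounds below may be only part of what the source reports. "The series", "measured", "known", "first", "only" and "open" are said of these compounds alone.

Compound 1 `O=C(c1nc2ccccc2s1)N1CCN(c2cnccn2)CC1` gives 65.3%. Compound 2 `COc1ccccc1N1CCN(C(=O)c2nc3ccccc3s2)CC1` gives 53.4%.

In an ADME assay on RAW264.7 cells (Mus musculus) for cytotoxicity, read by MTT assay, with a stated time of 72 h, tested at 50 ug/mL (a lower number here means less inhibition, a higher number more inhibition at the concentration tested (going by the name of the read-out)), compound 2 stands lowest of the two numbers measured; its nearest neighbour is compound 1, and the step of a number 11.9 percentage points lower from compound 1 to compound 2 (beyond the scatter) lies beyond the scatter. Compound 3 `O=C(c1nc2ccccc2s1)N1CCN(c2ccccc2)CC1` has not yet been measured in this assay. It differs from compound 2 by hydrogen in place of methoxy on an aromatic carbon. Among the measured compounds shown here, the only measured step, a number 11.9 percentage points lower from compound 1 to compound 2 (beyond the scatter), exchanges the whole ring on the amine nitrogen, so it bears only loosely on the removal of a methoxy group; no measured pair shows this change by itself. The account therefore expects a step of a number 1.6 percentage points higher from compound 2 to compound 3 (within the scatter) that stays within the scatter, with no clear direction. On that basis compound 3 is estimated to give 55% in this assay, within a range from 40% to 70%.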

Compound 3, a percentage reported as inhibition, at one concentration (the size of the read-out at that concentration, not a potency): 67.2%
Estimate against measurement, compound 3: 12.2 percentage points below, within the range that was stated.
By their numbers in this assay, from the lowest: compound 2; then compounds 1 and 3 (each within the scatter of the next).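

In this assay the change from 2-methoxyphenyl to phenyl can now be read by itself: taking off the methoxy group gives a number 13.8 percentage points higher from compound 2 to compound 3 (beyond the scatter) and so carries a change beyond the scatter. The step of a number 1.9 percentage points higher from compound 1 to compound 3 (within the scatter) stays within the scatter, so among these three compounds the lower number sits with the compound that carries the methoxy group, and exchanging pyrazin-2-yl for plain phenyl on the amine nitrogen shows no separable change. Nothing measured here gives a reason for the methoxy step.

The compounds shown leave open whether this step belongs to methoxy itself or would also appear with a fluorine, a hydroxyl or a methyl group on the same aromatic carbon. They also leave open whether an ethoxy group there would give a similar number.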